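The compounds below may be only part of what the source reports. "The series", "measured", "known", "first", "only" and "open" are said of these compounds alone.

Compound 1: `COc1cccc(-c2cccc(-c3cn4cccc(C(N)=O)c4n3)c2)c1` — < 1000 nM
Compound 2: `COc1cncc(-c2cccc(-c3cn4cccc(C(N)=O)c4n3)c2)c1` — < 1000 nM

Of the compounds shown here, two have been measured in a physicochemical assay for solubility, in phosphate buffer, with a stated time of 24 h, at pH 7.4; on this read-out higher numbers stand for higher solubility and lower numbers for lower solubility. Compound 1 carries the structure `COc1cccc(-c2cccc(-c3cn4cccc(C(N)=O)c4n3)c2)c1`, and in this assay compound 1 gives < 1000 nM, which is a limit of the assay rather than a number. Compound 2, `COc1cncc(-c2cccc(-c3cn4cccc(C(N)=O)c4n3)c2)c1`, differs from it by a 5-methoxypyridin-3-yl in place of 3-methoxyphenyl on an aromatic carbon; in this assay compound 2 gives < 1000 nM, again a limit and not a number. The step that the two limits leave unreadable from compound 1 to compound 2 therefore cannot be read. Where compound 2 stands is known only as this limit, and the single other value shown is a limit too; the limit of < 1000 nM in this assay, at which 2 of the 2 values shown sit, sums up the whole picture.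

Compound 3, `NC(=O)c1cccn2cc(-c3cccc(-c4cncc(OCC(F)F)c4)c3)nc12`, has not yet been measured. It differs from compound 2 by difluoromethyl in place of hydrogen on a saturated chain carbon bound to an oxygen on an aromatic ring. Going by the values given here, no measured step is readable, so no measured step bears on this change with a known size. The estimate for compound 3 therefore rests on compound 2 sitting at its limit < 1000 nM, with the step that the limit leaves unreadable from compound 2 to compound 3 expected to be small. Compound 3 is accordingly expected to give about 500 nM, within 100 nM to 2000 nM, most likely reported again as a limit.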

Compound 3, solubility: < 1000 nM
Compound 3 ended at the assay's limit; the forecaster's own chance of this, stated with the estimate: 80%; the middle value does not contradict the limit.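

In this assay compound 3 gives < 1000 nM, which is a limit of the assay and not a number. Compound 2 also stands at a limit, so no new step can be read between compound 2 and compound 3. The compounds shown leave open what their actual solubilities are and how far apart they lie, as all of them share one limit: the limit of < 1000 nM in this assay, at which 3 of the 3 values shown sit.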